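The compounds below may be only part of what the source reports. "The series", "measured", "known", "first", "only" and "open" are said of these compounds alone.

Measured compounds in the series:

compound 1, `C=C(CC)C(=O)c1ccc(OCc2nc(-c3ccc([N+](=O)[O-])cc3)cs2)c(C)c1C`, 4.4%
compound 2, `C=C(C)C(=O)c1ccc(OCc2nc(-c3ccc([N+](=O)[O-])cc3)cs2)c(C)c1C`, 17.2%
compound 3, `C=C(CC)C(=O)c1ccc(OCc2nc(-c3ccc4ccccc4c3)cs2)cc1Cl`, 9.5%

All three were run in an assay on HL-60 cells for inhibition of glutathione S-transferase P (Homo sapiens), read by spectrophotometry, tested at 5 uM; on this read-out lower numbers stand for less inhibition and higher numbers for more inhibition at the one concentration tested (going by the name of the read-out). Compound 1 gives 4.4% and compound 2 gives 17.2%. The two share a core and differ in one place, (hydrogen in place of methyl on a saturated chain carbon bound to a double-bonded chain carbon); that change gives a number 12.8 percentage points higher from compound 1 to compound 2 (beyond the scatter). Compound 3, on a different core, gives 9.5%. Compound 3 and compound 1 differ in more than one place, and the difference between the two cores is not broken down here. What the values show is that compound 3 and compound 1 lie within the scatter of each other, as do compound 3 and compound 2.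

Compound 4, `C=C(C)C(=O)c1ccc(OCc2nc(-c3ccc4ccccc4c3)cs2)cc1Cl`, has not yet been measured. Compound 4 differs from compound 3 by hydrogen in place of methyl on a saturated chain carbon bound to a double-bonded chain carbon, which is the same change as that from compound 1 to compound 2, made on the core of compound 3. Within the compounds shown, the change occurs only here and between compound 1 and compound 2, so the one measured step is the sole guide. For compound 4 a step of roughly the size of the measured one is expected, a number 8.5 percentage points higher from compound 3 to compound 4 (within the scatter). This rests on a number 12.8 percentage points higher from compound 1 to compound 2 (beyond the scatter) and on compound 3 giving 9.5%. The spread of the estimate is kept wide, since a single step on another core is thin support. Compound 4 is estimated at 18%, between 4% and 34%.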

Compound 4, a percentage reported as inhibition, at one concentration (the size of the read-out at that concentration, not a potency): 55.2%
For compound 4 the middle estimate is 37.2 percentage points below the measured one, and the stated range ends below it.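

The change, hydrogen in place of methyl on a saturated chain carbon bound to a double-bonded chain carbon (read one bond further out, ethyl to methyl), gives a number 45.7 percentage points higher from compound 3 to compound 4 (beyond the scatter) in this assay. The direction of the step carries over from one core to the other, but its size does not, so on these compounds a step measured on one core cannot be used as a size estimate on the other: the same change on two cores in this assay, a number 12.8 percentage points higher (beyond the scatter) from compound 1 to compound 2 and a number 45.7 percentage points higher (beyond the scatter) from compound 3 to compound 4, 32.9 percentage points apart, beyond the scatter of two such steps

Among the compounds shown here, what this does not show is which part of the two cores goes with the larger step, since the cores differ in more than one place and only one pair of compounds stands on each, so no step size can be inferred for a third core.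

The compounds shown leave open whether the larger step follows from a single difference between the cores, which only compounds that split those differences one at a time could settle. They also leave open how the read-out behaves at the same place with a longer chain such as propyl, or with a polar group such as an amine or a carboxylic acid on that chain.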